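The source may hold more compounds than are shown below. What is called first, only, known or untested is meant among the compounds shown, and "the series" means these compounds.

Values in an ADME assay on microsomes from liver (Homo sapiens) for metabolic stability; a lower number here means slower removal, a higher number faster removal of the compound:
- Compound 1 `COc1ccc([C@H](C)NC(=O)Cn2nnc3ccccc3c2=O)cc1`: 13 mL/min/kg
- Compound 2 `Cc1ccc([C@H](C)NC(=O)Cn2nnc3ccccc3c2=O)cn1`: < 9.9 mL/min/kg (a limit of the assay, not a number)

Compound 2 has no exact value, only the limit < 9.9 mL/min/kg. Its standing so far is the limit of < 9.9 mL/min/kg in this assay, at which 1 of the 2 values shown sits.

The next structure is compound 3 `Cc1ccc([C@H](C)NC(=O)Cn2nnc3ccccc3c2=O)c(C)c1`, which has 2,4-dimethylphenyl in place of 6-methylpyridin-3-yl on a saturated chain carbon bound to an amide-type nitrogen and a saturated chain carbon. The count of what changes is 2,4-dimethylphenyl in place of 6-methylpyridin-3-yl on a saturated chain carbon bound to an amide-type nitrogen and a saturated chain carbon.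

Going by the values given here, only one measured step bears on this change, at the same place on the molecule: an at least 1.3-fold lower number from compound 1 to compound 2 (0.11 log units; that floor lies within the scatter). It replaced 4-methoxyphenyl with 6-methylpyridin-3-yl, and it does not clear the usual scatter, so it is weak evidence.

Compound 3 again has a six-membered aromatic ring of carbon only, as compound 1 does at 13 mL/min/kg, so a value near that one is expected. The expected step, towards a higher number and faster removal, is an at least 1.6-fold higher number from compound 2 to compound 3 (0.20 log units; that floor lies within the scatter). For compound 3 the estimate is 16 mL/min/kg, with an expected range of 9 mL/min/kg to 30 mL/min/kg.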

Compound 3, clearance: 33 mL/min/kg
Beside the measured number, compound 3's estimate is 2.1-fold (0.31 log units) below it; measured number above the stated range.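

In this assay, the place on a saturated chain carbon bound to an amide-type nitrogen and a saturated chain carbon now shows a change that clears the usual scatter: with 2,4-dimethylphenyl in place of 6-methylpyridin-3-yl, the result is an at least 3.3-fold higher number from compound 2 to compound 3 (0.52 log units; beyond the scatter). A ring of carbon only does not by itself match compound 1, since 2,4-dimethylphenyl in place of 4-methoxyphenyl gives a 2.5-fold higher number from compound 1 to compound 3 (0.40 log units; beyond the scatter), a difference between two carbon-only rings that the earlier step could not reveal. The first of these steps is only a floor, as compound 2 has a limit of the assay rather than a number: the limit of < 9.9 mL/min/kg in this assay, at which 1 of the 3 values shown sits.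

2,4-dimethylphenyl differs from 6-methylpyridin-3-yl both in the ring nitrogen and in its methyl groups, and the compounds shown do not separate these two differences. A plain phenyl or a 4-methylphenyl group at this place would help to show how much of the faster removal goes with each one.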